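Ring-nitrogen substituent change: compound 3 to compound 4

A few compounds are considered here, and "the series" means these few. Any claim that something is new, unique, unknown or untested is made for them only; others in the source may bear on it.

Numbers so far in a functional assay on MGC-803 cells (Homo sapiens) for antiproliferative activity, read by CCK-8 assay, with a stated time of 72 h, tested at 2 uM; on this read-out higher numbers stand for a stronger effect at the one concentration tested and lower numbers for a weaker effect:
- compound 1 `Nc1ccccc1NC(=O)c1ccc(CSC(=S)N2CCN(Cc3ccncc3)CC2)cc1`: 18.4%
- compound 2 `Nc1ccccc1NC(=O)c1ccc(CSC(=S)N2CCN(c3ccc(F)cc3)CC2)cc1`: 18.8%
- compound 3 `Nc1ccccc1NC(=O)c1ccc(CSC(=S)N2CCN(c3ccccc3F)CC2)cc1`: 33.7%

Compound 3 stands highest of the three numbers. The nearest number is that of compound 2, and the gap lies beyond the scatter (a number 14.9 percentage points higher from compound 2 to compound 3 (beyond the scatter)); compound 1 is furthest away (a number 15.3 percentage points higher from compound 1 to compound 3 (beyond the scatter)). Compounds 1 and 2 lie within the scatter of one another (a number 0.4 percentage points higher from compound 1 to compound 2 (within the scatter)), so no order between them can be read.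

Compound 4 `Nc1ccccc1NC(=O)c1ccc(CSC(=S)N2CCN(Cc3cccnc3)CC2)cc1` differs from compound 3 in one place: (pyridin-3-yl)methyl in place of 2-fluorophenyl on an amine nitrogen in a ring. The measured step that bears on this is a number 15.3 percentage points higher from compound 1 to compound 3 (beyond the scatter), which runs the opposite way: a (pyridin-4-yl)methyl group on the ring nitrogen gave the lower number and the 2-fluorophenyl the higher. Compound 4 carries a (pyridin-3-yl)methyl group, which matches the group of compound 1 in what is counted, ring and heavy atoms alike. In this assay the number for compound 4 is therefore expected to fall back by roughly the size of that step, a number 14.7 percentage points lower from compound 3 to compound 4 (beyond the scatter). Compound 4 is estimated at 19%, with a range from 8% to 32%. Among the measured compounds shown here, no measured compound carries a (pyridin-3-yl)methyl group, so this expectation rests on a single step.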

Compound 4, a percentage reported as inhibition, at one concentration (the size of the read-out at that concentration, not a potency): 37.7%
Compound 4: the middle estimate sits 18.7 percentage points below what was measured; measured number above the stated range.
By their numbers in this assay, from the lowest: compounds 1 and 2 (each within the scatter of the next); then compounds 3 and 4 (each within the scatter of the next).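

Notes on the amine nitrogen in the ring, in this assay: the change of pyridin-4-yl to pyridin-3-yl on the saturated chain carbon gives a number 19.3 percentage points higher from compound 1 to compound 4 (beyond the scatter) and is the first sign that this position responds to where the ring is attached to the chain, even though the heavy-atom count of the group stays the same. Against the aryl groups, the (pyridin-3-yl)methyl group gives a number 4 percentage points higher from compound 3 to compound 4 (within the scatter) and so cannot be ordered against 2-fluorophenyl, whereas a number 18.9 percentage points higher from compound 2 to compound 4 (beyond the scatter) sets it apart from 4-fluorophenyl. Neither group type therefore tracks the read-out across these four compounds, since the lower pair holds compound 1 and compound 2, the upper pair holds compound 3 and compound 4, and each pair contains one (pyridinyl)methyl and one fluorophenyl group.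

No measurement at hand gives a reason for the gap between the two pyridine isomers. Open, from the compounds shown here alone, is whether a (pyridin-2-yl)methyl or a plain benzyl group on the same nitrogen would fall with the lower or the upper pair, and readings at a single concentration say nothing about potency.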